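The source may hold more compounds than are shown below. What is called first, only, known or untested is meant among the compounds shown, and "the series" means these compounds.

Measured so far:
compound 1 `CN1CCN(CC(=O)NC2(c3ccc(Cl)cc3)C(=O)Nc3cc(Cl)ccc32)CC1` in an in vitro functional assay on CHO-CREluc cells for antagonist activity at growth hormone secretagogue receptor type 1 (Homo sapiens), read by a luciferase reporter, with a stated time of 4 h; a higher number here means a weaker inhibitor, a lower number a stronger inhibitor: 140 nM
compound 2 `CCN1CCCC(CC(=O)NC2(c3ccc(Cl)c(Cl)c3)C(=O)Nc3cc(Cl)cc(Cl)c32)C1` in this assay: 47 nM

Compound 2 stands lowest of the two numbers; compound 1 sits beyond the scatter above it. Compound 3 `CCN1CCN(CC(=O)NC2(c3ccc(Cl)c(Cl)c3)C(=O)Nc3cc(Cl)cc(Cl)c32)CC1` is not yet measured. It differs from compound 2 in one place: 4-ethylpiperazin-1-yl in place of 1-ethylpiperidin-3-yl on a saturated chain carbon bound to a carbonyl carbon. Going by the values given here, no measured pair covers this change, so only a modest step in this assay is expected, if anything toward a higher number, and it may well stay within the scatter. The expected step is a 1.5-fold higher number from compound 2 to compound 3 (0.17 log units; within the scatter). Compound 3 is estimated at 70 nM, with a range from 25 nM to 200 nM.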

Compound 3, half-maximal inhibitory concentration: 7 nM
Beside the measured number, compound 3's estimate is 10-fold (1.00 log units) above it; the measured number lies below the stated range.
By their numbers in this assay, from the lowest: compound 3; then compound 2; then compound 1.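

On the saturated chain carbon bound to a carbonyl carbon, the choice of ring amine counts for much in this assay: 4-ethylpiperazin-1-yl in place of 1-ethylpiperidin-3-yl gives a 6.7-fold lower number from compound 2 to compound 3 (0.83 log units; beyond the scatter). The two groups have the same heavy-atom count, so this step comes with no change in that count. No measurement on hand accounts for the step.

On these data alone, whether 4-isopropylpiperazin-1-yl or morpholin-4-yl at this place would hold the number of compound 3 remains open. Compound 1 differs from compound 3 in more than one place, so the contribution of the chlorines on the core also stays unresolved.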